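Swapping the benzyl group for a cyclopropylmethyl arm

The compounds below may be only part of what the source reports. "The series", "measured", "known", "first", "only" and "open" are said of these compounds alone.

Compound 1 `COc1cc2c(=O)c(C(=O)c3ccc(C)cc3)cn(Cc3ccc(C(C)C)cc3)c2cc1OC` was tested in an ADME assay on Huh-7 cells (Homo sapiens) for cytotoxicity; on this read-out higher numbers stand for weaker inhibition of growth and lower numbers for stronger inhibition of growth. In this assay compound 1 gives 15500 nM. For the measured compounds named here, that is the only number available here: compound 2 `COc1cc2c(=O)c(S(=O)(=O)CCc3ccc(Cl)cc3)cn(Cc3ccccc3)c2cc1OC` was also examined, but for it the result is reported only as "not active" (no number reported), without a concentration, so compound 1 cannot be placed against it in any order.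

Compound 3 `COc1cc2c(=O)c(C(=O)c3ccc(C)cc3)cn(CC3CC3)c2cc1OC` has not yet been measured. It differs from compound 1 in a single place: cyclopropyl in place of 4-isopropylphenyl on a saturated chain carbon bound to an aromatic nitrogen. In the wider reading of the same change, a 4-isopropylbenzyl group becomes a cyclopropylmethyl group, while the shared core and the rest of the molecule stay as they are.

Going by the values given here, no pair of measured compounds shows this kind of change, so there is no measured step to lean on. The expectation is that compound 3 lands close to compound 1, with any shift more likely toward weaker inhibition of growth than toward stronger, and the step of a 1.6-fold higher number from compound 1 to compound 3 (0.21 log units; within the scatter) is estimated to stay modest. On that basis compound 3 is expected to give about 25000 nM, with a range from 8000 nM to 80000 nM, and a fair chance that only a limit is reported.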

Compound 3, concentration for 50% growth inhibition: "not active" (no number reported)
Compound 3: no number reported; there is nothing to compare the estimate with.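

In this assay, for the compounds shown here, compound 3 is reported only as "not active", without a concentration, so no step from compound 1 to compound 3 can be read. Nothing measured here helps to explain this result. The compounds shown leave open how far changing 4-isopropylbenzyl to cyclopropylmethyl moves growth inhibition in numbers.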